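A few compounds are considered here, and "the series" means these few. Any claim that something is new, unique, unknown or untested is made for them only; others in the source may bear on it.

Measured compounds:
Compound 1, `O=C1O[C@H]([C@@H](O)Cn2cc(-c3ccc(Br)cc3)nn2)C(OCc2ccccc2)=C1OCc1ccccc1`: 5830 nM in a functional assay on CFPAC-1 cells (Homo sapiens) for antiproliferative activity, read by MTT assay, with a stated time of 72 h; on this read-out higher numbers stand for weaker inhibition and lower numbers for stronger inhibition
Compound 2, `O=C1O[C@H]([C@@H](O)Cn2cc(CNS(=O)(=O)c3ccc(Cl)cc3)nn2)C(OCc2ccccc2)=C1OCc1ccccc1`: 38900 nM in this assay

Going by the values given here, compound 2 stands at the highest of the two numbers; the only measured step, a 6.7-fold higher number from compound 1 to compound 2 (0.82 log units; beyond the scatter), separates it from compound 1. Compound 3, `COc1ccc(-c2cn(C[C@H](O)[C@H]3OC(=O)C(OCc4ccccc4)=C3OCc3ccccc3)nn2)cc1`, differs from compound 2 by 4-methoxyphenyl in place of (((4-chlorophenyl)sulfonyl)amino)methyl on an aromatic carbon. This change brings compound 3 closer to compound 1 than to compound 2, so the step from compound 1 to compound 2 bears on it in reverse, and a downward step of roughly that size is expected. Compound 3 is therefore expected to show a 6.0-fold lower number from compound 2 to compound 3 (0.78 log units; beyond the scatter). Compound 3 is estimated at 6500 nM in this assay, with a range of 2000 nM to 20000 nM.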

Compound 3, half-maximal inhibitory concentration: 26000 nM
Compound 3: middle estimate off by 4.0-fold (0.60 log units), on the low side, and the stated range ends below it.
By their numbers in this assay, from the lowest: compound 1; then compounds 3 and 2 (each within the scatter of the next).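

Methoxy in place of bromo gives a 4.5-fold higher number from compound 1 to compound 3 (0.65 log units; beyond the scatter), so in this assay an aryl group on this aromatic carbon does not by itself keep the number of compound 1; the group on that aryl ring counts. Swapping (((4-chlorophenyl)sulfonyl)amino)methyl for 4-methoxyphenyl gives a 1.5-fold lower number from compound 2 to compound 3 (0.17 log units; within the scatter), so these two groups are not told apart here. No evidence on hand accounts for either step.

Open, on these data alone, is whether an amine or a carboxylic acid in place of bromo would stay with compound 1 or with compound 3. Also open, as far as these compounds go, is whether chloro in place of bromo would change the number.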